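Shortening the Chain: From Chlorobutanamide to Acrylamide

The compounds below may be only part of what the source reports. "The series", "measured", "known", "first", "only" and "open" are said of these compounds alone.

Three anilides built on a shared core have been tested in a functional assay on M21 cells (Homo sapiens) for antiproliferative activity, with a stated time of 48 h; a lower number here means a stronger inhibitor, a higher number a weaker inhibitor. Compound 1 `CCCCC(OC)c1cccc(NC(=O)CCl)c1` gives 6900 nM in this assay. Compound 2 `CCCCC(OC)c1cccc(NC(=O)CCCl)c1` returns only a limit, > 100000 nM in this assay. Compound 3 `CCCCC(OC)c1cccc(NC(=O)CCCCl)c1` likewise returns only a limit, > 100000 nM in this assay. Hence the step of an at least 14-fold higher number from compound 1 to compound 2 (1.16 log units; beyond the scatter) and the step of an at least 14-fold higher number from compound 1 to compound 3 (1.16 log units; beyond the scatter): each lengthening of the chloro-bearing chain cost activity. The step that the two limits leave unreadable from compound 2 to compound 3 cannot be sized because both values sit at the limit of > 100000 nM in this assay, at which 2 of the 3 values shown sit. Compound 3 therefore stands at the limit of this assay, no better than compound 2 and far behind compound 1.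

Compound 4 `C=CC(=O)Nc1cccc(C(CCCC)OC)c1` differs from compound 3 by vinyl in place of 3-chloropropyl on a carbonyl carbon. This change runs opposite to the lengthening seen from compound 1, where the steps to compound 2 and compound 3 were large losses. A large gain in this assay is therefore expected, and the step of an at least 20-fold lower number from compound 3 to compound 4 (1.30 log units; beyond the scatter) is what that estimate means. Compound 4 is expected to give about 5000 nM, with a range from 1000 nM to 30000 nM.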

Compound 4, half-maximal inhibitory concentration: 48000 nM
The estimate for compound 4 lay 9.6-fold (0.98 log units) below the measured number; measured number outside the range, above it.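

In this assay, a chain-free vinyl group on the carbonyl carbon brings the anilide back to a readable value, with an at least 2.0-fold lower number from compound 3 to compound 4 (0.31 log units; beyond the scatter) and an at least 2.0-fold lower number from compound 2 to compound 4 (0.31 log units; beyond the scatter). Both steps are only lower bounds, set by a limit of the assay and not by a number: the limit of > 100000 nM in this assay, at which 2 of the 4 values shown sit. Yet vinyl does not match the shortest chloro-bearing group, with a 7.0-fold higher number from compound 1 to compound 4 (0.84 log units; beyond the scatter), so on this carbonyl carbon chloromethyl remains the best of the groups shown.

The compounds shown leave open how a plain methyl or a bromomethyl group on the same carbonyl carbon would compare with chloromethyl and vinyl. They also leave open whether compound 1 would stay ahead of compound 4 if a hydroxyl group replaced the methoxy group on the shared core.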